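Methylation of the azaindole nitrogen in compound 2

The source may hold more compounds than are shown below. What is called first, only, known or untested is meant among the compounds shown, and "the series" means these compounds.

Compound 2 `O=C(Nc1ccc(Oc2ccnc3[nH]ccc23)cc1)c1cc2cccnc2n(-c2ccc(Br)cc2F)c1=O` holds the second highest of the three numbers in a functional assay on A549 cells (Homo sapiens) for antiproliferative activity, read by MTT assay, with a stated time of 72 h (a lower number here means a stronger inhibitor, a higher number a weaker inhibitor), giving 1570 nM; compound 1 `O=C(Nc1ccc(Oc2ccnc3[nH]ccc23)cc1)c1cc2cccnc2n(-c2ccc(F)c(Cl)c2)c1=O` gives 680 nM and compound 3 `O=C(Nc1ccc(Oc2ccnc3[nH]ccc23)cc1)c1cc2cccnc2n(-c2ccc(C(F)(F)F)cc2Cl)c1=O` gives 3230 nM. The steps of a 2.3-fold higher number from compound 1 to compound 2 (0.36 log units; beyond the scatter) and a 2.1-fold higher number from compound 2 to compound 3 (0.31 log units; beyond the scatter) both change only the aryl group on the pyridone nitrogen. Compound 4 `Cn1ccc2c(Oc3ccc(NC(=O)c4cc5cccnc5n(-c5ccc(Br)cc5F)c4=O)cc3)ccnc21` differs from compound 2 by methyl in place of hydrogen on an aromatic nitrogen. Going by the values given here, no measured step touches this position, so the three aryl steps offer no guide to its size. With nothing comparable to draw on, the author expects a change no larger than modest, in either direction, and puts compound 4 at 2200 nM, between 700 nM and 7000 nM, a step of a 1.4-fold higher number from compound 2 to compound 4 (0.15 log units; within the scatter) that is as likely as not to lie within the scatter.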

Compound 4, half-maximal inhibitory concentration: 1630 nM
Compound 4: the middle estimate sits 1.3-fold (0.13 log units) above what was measured; measured number inside the range.
By their numbers in this assay, from the lowest: compound 1; then compounds 2, 4 and 3 (each within the scatter of the next, the first and the last beyond it).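

Going by these compounds alone, the first step at this position, a 1.0-fold higher number from compound 2 to compound 4 (0.02 log units; within the scatter), shows that in this assay the hydrogen on the aromatic nitrogen can give way to methyl without a shift beyond the scatter. This holds for one pair only, with the 4-bromo-2-fluorophenyl group on the pyridone nitrogen. No outside evidence bears on this result. The compounds shown leave open whether a longer chain, or a chain ending in an amine, would be tolerated on this nitrogen. They also leave open whether methyl would behave alike with the 3-chloro-4-fluorophenyl group of compound 1.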